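The source may report more compounds than this note shows. Statements on the series, on what has been measured and on what is new or still open speak of the compounds shown alone.

Compound 1 `COc1ccc(/C=C/C(=O)c2cc3ccc(OCc4cccc(OC)c4)cc3oc2=O)cc1`: in a functional assay on MCF7 cells (Homo sapiens) for cytotoxicity, read by MTT assay, with a stated time of 72 h (on this read-out lower numbers stand for stronger inhibition and higher numbers for weaker inhibition), compound 1 reaches only the assay limit of > 100000 nM.
Compound 2 `COc1cccc(COc2ccc3cc(C(=O)/C=C/c4ccc(Cl)cc4Cl)c(=O)oc3c2)c1`: in this assay compound 2 is recorded as "not determined" (no result reported).
Compound 3 `COc1cccc(COc2ccc3cc(C(=O)/C=C/c4c(Cl)cccc4Cl)c(=O)oc3c2)c1`: in this assay compound 3 gives 10100 nM.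

Going by the values given here, compound 3 therefore stands as the only compound with a single number in this assay; compound 1 sits at a limit (the limit of > 100000 nM in this assay, at which 1 of the 3 values shown sits), and compound 2 has no result. Among the compounds with values here, the one measured step, an at least 9.9-fold lower number from compound 1 to compound 3 (0.99 log units; beyond the scatter), runs from a methoxy-bearing phenyl at the limit to the 2,6-dichlorophenyl with a number.

Compound 4 `COc1cccc(COc2ccc3cc(C(=O)/C=C/c4cc(OC)ccc4OC)c(=O)oc3c2)c1` differs from compound 3 in that (2,5-dimethoxyphenyl in place of 2,6-dichlorophenyl on a double-bonded chain carbon bound to a double-bonded chain carbon). Within the data shown here, no measured step covers this exact exchange, but it bears on the step of an at least 9.9-fold lower number from compound 1 to compound 3 (0.99 log units; beyond the scatter), since it removes the dichlorophenyl and brings methoxy groups back onto the ring. A rise in the number toward the limit is therefore expected, because an at least 9.9-fold lower number from compound 1 to compound 3 (0.99 log units; beyond the scatter) went the other way when the dichlorophenyl entered. Compound 4 is expected to show a 5.0-fold higher number from compound 3 to compound 4 (0.69 log units; beyond the scatter) in this assay. For compound 4 the estimate in this assay is 50000 nM, with a range from 15000 nM to 160000 nM.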

Compound 4, half-maximal inhibitory concentration: > 100000 nM
Compound 4: only a limit was reported; the forecaster's own chance of this, stated with the estimate: 45%; middle value at least 2.0-fold (0.30 log units) away from the limit.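

In this assay, the exchange on a double-bonded chain carbon bound to a double-bonded chain carbon gives an at least 9.9-fold higher number from compound 3 to compound 4 (0.99 log units; beyond the scatter), so a second methoxy-bearing ring, 2,5-dimethoxyphenyl, also fails to keep the number that 2,6-dichlorophenyl gave. Compound 4 reaches only a limit, > 100000 nM, and the step between compound 1 and compound 4 cannot be read. Among the compounds with a result, only compound 3 lies clear of this limit: the limit of > 100000 nM in this assay, at which 2 of the 4 values shown sit.

On these data alone, whether the number in this assay depends on the two chlorines as such stays open, as compound 2, with its other dichlorophenyl, has no result. Also open, as far as these compounds go, is whether a phenyl ring carrying a single fluorine, a nitrile or an amine would give a number lower than that of compound 3.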